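The compounds below may be only part of what the source reports. "The series", "measured", "known", "first", "only" and "open" are said of these compounds alone.

In a functional assay (strain AB) with Danio rerio as the target, read by microscopy, with a stated time of 1 h (on this read-out higher numbers stand for an effect only at larger amounts of compound and lower numbers for an effect already at smaller amounts), compound 1 (`CCN1CCc2c(sc(NC(=O)Nc3ccc(Cl)cc3)c2C(N)=O)C1`) gives 3120 nM. Compound 2 (`NC(=O)c1c(NC(=O)Nc2ccc(Cl)cc2)sc2c1CCN(CC1CCCCC1)C2`) gives 1890 nM, and the two values do not separate: the series shows a 1.7-fold lower number from compound 1 to compound 2 (0.22 log units; within the scatter). Compound 3 (`CCN1CCc2c(sc(NC(=O)Nc3ccc(Cl)cc3)c2C(=O)O)C1`) gives > 25000 nM, which is a limit and not a number. The carbonyl change shows an at least 8.0-fold higher number from compound 1 to compound 3 (0.90 log units; beyond the scatter). Compound 4 (`CCN1CCc2c(sc(NC(=O)Nc3ccc(C(F)(F)F)cc3)c2C(N)=O)C1`) differs from compound 1 as follows: trifluoromethyl in place of chloro on an aromatic carbon. Neither measured step touches this aromatic carbon, so neither gives a direct size for the change, and no step beyond the scatter is expected. The expected change is a 1.1-fold lower number from compound 1 to compound 4 (0.05 log units; within the scatter). For compound 4 the estimated value is 2800 nM, with an expected range of 1000 nM to 8000 nM.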

Compound 4, half-maximal effective concentration: 2910 nM
The estimate for compound 4 lay 1.0-fold (0.02 log units) below the measured number; the measured number falls inside the stated range.
By their numbers in this assay, from the lowest: compounds 2, 4 and 1 (each within the scatter of the next). At a limit, above all of these: compound 3.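

Trifluoromethyl in place of chloro on the aromatic carbon gives a 1.1-fold lower number from compound 1 to compound 4 (0.03 log units; within the scatter) in this assay, the first direct reading at this position in the series. With four heavy atoms entering for one, the two compounds do not separate, so this pair tolerates the larger group at this position. No measurement shown bears on why the two groups read alike. Still open, going by these compounds, is whether an amine or a methoxy group on this aromatic carbon would also stay within the scatter of compound 1. Plain hydrogen there remains equally open.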